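The source may report more compounds than this note shows. Statements on the series, on what has been measured and on what is new or still open speak of the compounds shown alone.

Of the compounds shown here, three sharing one core have been measured in a functional assay on HT-29 cells (Homo sapiens) for antiproliferative activity, read by MTT assay, with a stated time of 72 h; a higher number here means a weaker inhibitor, a lower number a stronger inhibitor. Compound 1 `CNC(=O)c1cc(Oc2ccc(NC(=O)c3cc4cccnc4n(-c4ccc(F)cc4)c3=O)cc2)ccn1` gives 160 nM, compound 2 `CCNC(=O)c1cc(Oc2ccc(NC(=O)c3cc4cccnc4n(-c4ccccc4)c3=O)cc2)ccn1` gives 220 nM, and compound 3 `CCNC(=O)c1cc(Oc2ccc(NC(=O)c3cc4cccnc4n(-c4ccccc4F)c3=O)cc2)ccn1` gives 260 nM. Compound 3 has the highest number of the three, yet its distances to compound 2 and to compound 1 both lie within the scatter, so no ordering among them can be claimed. The step now considered leads to compound 4 `CCNC(=O)c1cc(Oc2ccc(NC(=O)c3cc4cccnc4n(-c4ccc(F)cc4)c3=O)cc2)ccn1`, which differs from compound 3 only in where the fluorine sits: 4-fluorophenyl in place of 2-fluorophenyl on an aromatic nitrogen. For the measured compounds named here, the single measured step that touches this ring, a 1.2-fold higher number from compound 2 to compound 3 (0.07 log units; within the scatter), stayed within the scatter. Compound 1 also carries the 4-fluorophenyl group and gives 160 nM, close to the others. The step from compound 3 to compound 4 is therefore expected to be a 1.2-fold lower number from compound 3 to compound 4 (0.09 log units; within the scatter), nothing beyond the scatter. In this assay compound 4 is estimated at 210 nM, with a range from 110 nM to 400 nM.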

Compound 4, half-maximal inhibitory concentration: 190 nM
The estimate for compound 4 lay 1.1-fold (0.04 log units) above the measured number, and the stated range covers the measured number.
By their numbers in this assay, from the lowest: compounds 1, 4, 2 and 3 (each within the scatter of the next).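

In this assay, moving the fluorine around the ring on the aromatic nitrogen gives a 1.4-fold lower number from compound 3 to compound 4 (0.14 log units; within the scatter) and so leaves the 2-fluorophenyl and 4-fluorophenyl compounds indistinguishable, while fluoro in place of hydrogen on that ring gives a 1.2-fold lower number from compound 2 to compound 4 (0.06 log units; within the scatter) as a second small step. With 4-fluorophenyl held constant, methyl in place of hydrogen on the chain carbon bound to the amide nitrogen gives a 1.2-fold higher number from compound 1 to compound 4 (0.07 log units; within the scatter) as well. No measurement here explains these results. Open, on these data alone, is whether a larger group on this ring, such as methoxy or trifluoromethyl, or a longer chain on the amide nitrogen would move the number beyond the scatter.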